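Amide series: fluorine on the N-aryl ring of compound 2

The source may hold more compounds than are shown below. What is called first, only, known or untested is meant among the compounds shown, and "the series" means these compounds.

Measured so far in a functional assay on NCI-H460 cells (Homo sapiens) for antiproliferative activity, read by MTT assay, with a stated time of 72 h; a higher number here means a weaker inhibitor, a lower number a stronger inhibitor:
compound 1 `O=C(Nc1ccc(Oc2ccnc3[nH]ccc23)cc1)c1cc2cccnc2n(-c2ccc(F)cc2)c1=O`: 190 nM
compound 2 `Cn1ccc2c(Oc3ccc(NC(=O)c4cc5cccnc5n(-c5ccccc5)c4=O)cc3)ccnc21`: 560 nM

Compound 2 stands at the higher of the two numbers in this assay; the nearest is compound 1, whose value is lower by more than the usual scatter. Compound 1 and compound 2 differ in two places at once, so the two values together do not isolate the effect of either change.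

Compound 3 `Cn1ccc2c(Oc3ccc(NC(=O)c4cc5cccnc5n(-c5ccc(F)cc5)c4=O)cc3)ccnc21` differs from compound 2 in one place only: fluoro in place of hydrogen on an aromatic carbon, para to a large group. Within the data shown here, no measured pair shows this change alone. A step of this kind is expected to be small, likely within the scatter, with at most a modest lowering of the number. Compound 3 is therefore expected to give about 400 nM in this assay, within 150 nM to 1100 nM, which means an expected step of a 1.4-fold lower number from compound 2 to compound 3 (0.15 log units; within the scatter).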

Compound 3, half-maximal inhibitory concentration: 260 nM
Compound 3: the middle estimate sits 1.5-fold (0.19 log units) above what was measured, within the range that was stated.
By their numbers in this assay, from the lowest: compounds 1 and 3 (each within the scatter of the next); then compound 2.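

In this assay, phenyl to 4-fluorophenyl gives a 2.2-fold lower number from compound 2 to compound 3 (0.33 log units; beyond the scatter) and so gives the fluoro on this ring, para to a large group, a step of its own, modest but beyond the scatter. With that fluoro kept, methyl in place of hydrogen on the aromatic nitrogen gives a 1.4-fold higher number from compound 1 to compound 3 (0.14 log units; within the scatter) and stays within the scatter, so this pair shows no separable effect of that methyl. No data given here bear on why the fluoro step arises.

As far as these compounds go, the fluoro step rests on a single pair, so whether it also holds with hydrogen on the aromatic nitrogen remains open. Also open, from the compounds shown here alone, is how chloro or methoxy in place of the fluoro, or a longer chain such as ethyl in place of the methyl, would read in this assay.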